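The source may report more compounds than this note shows. Statements on the series, on what has been measured and on what is new or still open speak of the compounds shown alone.

In a functional assay on ZR-75-1 cells (Homo sapiens) for cytotoxicity, read by MTT assay, with a stated time of 72 h (on this read-out lower numbers stand for an effect already at smaller amounts and higher numbers for an effect only at larger amounts of compound), compound 1 `CCc1cccc2c(O)c(-c3occ(C)c3C(=O)O)ccc12` gives 0.3 ug/mL, and compound 3 `CCc1cccc2c(OC)c(-c3occ(C)c3C(=S)OC)ccc12` gives 5.8 ug/mL. Compound 2 `CCOc1c(-c2occ(C)c2C(=O)O)ccc2c(CC)cccc12` reaches only the limit > 10 ug/mL in this assay. On these data alone, the step of an at least 33-fold higher number from compound 1 to compound 2 (1.52 log units; beyond the scatter) shows how far compound 2 stands from compound 1, though with compound 2 sitting at the limit of > 10 ug/mL in this assay, at which 1 of the 3 values shown sits, the true size of that step remains open. Compound 4 `CCOc1c(-c2occ(C)c2CO)ccc2c(CC)cccc12` differs from compound 2 by hydroxymethyl in place of carboxy on an aromatic carbon. Among the measured compounds shown here, no measured step covers this change, and compound 3 is not a single-step neighbour of compound 2 or compound 4. The expectation therefore rests on compound 2 alone. The step that the limit leaves unreadable from compound 2 to compound 4 is expected to be small. Compound 4 is estimated at 15 ug/mL, within 4 ug/mL to 50 ug/mL, most likely again reported only as a limit.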

Compound 4, concentration for half-maximal effect: 1.4 ug/mL
Beside the measured number, compound 4's estimate is 11-fold (1.03 log units) above it; measured number below the stated range.
By their numbers in this assay, from the lowest: compound 1; then compound 4; then compound 3. At a limit, above all of these: compound 2.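

In this assay, hydroxymethyl in place of carboxy on this aromatic carbon gives an at least 7.1-fold lower number from compound 2 to compound 4 (0.85 log units; beyond the scatter). The earlier compounds shown here showed only a loss when ethyl replaced hydrogen on the oxygen, whereas this result shows that, with that ethyl in place, a carboxy group at this position is not needed for an effect. The full size of the step cannot be read because compound 2 sits at a limit: the limit of > 10 ug/mL in this assay, at which 1 of the 4 values shown sits.

On these data alone, it remains open whether hydroxymethyl would have the same effect on the core of compound 1. As far as these compounds go, what an amide or an aminomethyl group would give at this carbon also remains open.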